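The compounds below may be only part of what the source reports. "The series", "measured", "known", "first", "only" and "open" are said of these compounds alone.

Compound 1 `CC(C)N(Cc1ccc(C(=O)NO)cc1)S(=O)(=O)c1c(F)c(F)c(F)c(F)c1F` gives 4.32 nM in an assay on Sf9 cells for inhibition of protein deacetylase HDAC6 (Homo sapiens), read by fluorescence and mobility shift assay; a higher number here means a weaker inhibitor, a lower number a stronger inhibitor.
Compound 2 `CC(C)N(Cc1ccc(C(=O)NO)cc1)Cc1cc(F)c(F)c(F)c1F` gives 16.2 nM in this assay.
Compound 3 `COCCN(Cc1ccc(C(=O)NO)cc1)S(=O)(=O)c1cc(F)c(F)c(F)c1F` gives 27.8 nM in this assay.

Among these three numbers, compound 3 carries the highest. Its nearest neighbour is compound 2, which lies within the scatter of it, while compound 1 lies well beyond the scatter with the lowest number of the set. Compound 4 `CC(C)N(Cc1ccc(C(=O)NO)cc1)S(=O)(=O)c1cc(F)c(F)c(F)c1F` has not yet been measured. It differs from compound 3 in one place: isopropyl in place of 2-methoxyethyl on a sulfonamide nitrogen. Within the data shown here, no step between measured compounds covers this change, so the expectation rests on the compounds as they stand. The step of a 3.1-fold lower number from compound 3 to compound 4 (0.49 log units; beyond the scatter) is expected to run downward beyond the scatter, because compound 1, which also carries the isopropyl group, gives 4.32 nM. Compound 4 is thus estimated at 9 nM, within a range of 4 nM to 22 nM.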

Compound 4, half-maximal inhibitory concentration: 6 nM
Beside the measured number, compound 4's estimate is 1.5-fold (0.18 log units) above it; the range from low to high includes it.
By their numbers in this assay, from the lowest: compounds 1 and 4 (each within the scatter of the next); then compounds 2 and 3 (each within the scatter of the next).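

In this assay, with a 4.6-fold lower number from compound 3 to compound 4 (0.67 log units; beyond the scatter) as its measure, isopropyl in place of 2-methoxyethyl on a sulfonamide nitrogen now has a one-place step, and it lies beyond the scatter. By contrast, a 1.4-fold higher number from compound 1 to compound 4 (0.14 log units; within the scatter) for hydrogen in place of fluoro on an aromatic carbon stays within the scatter. No measured evidence accounts for either step.

Still open, going by these compounds, is how ethyl, cyclopropyl or a 2-aminoethyl chain on this sulfonamide nitrogen would compare with isopropyl.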